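Trifluoromethyl Substitution in an EP1 Antagonist Series

The compounds below may be only part of what the source reports. "The series", "measured", "known", "first", "only" and "open" are said of these compounds alone.

Compound 1 `O=C(O)c1ccn(Cc2cc(Br)ccc2OCc2ccccc2)n1` is the reference point of this set. In a functional assay on CHO-K1 cells for antagonist activity at prostaglandin E2 receptor EP1 subtype (Homo sapiens), read by FLIPR (a higher number here means a weaker inhibitor, a lower number a stronger inhibitor), compound 1 gives 55 nM. Compound 2 `O=C(O)c1nn(Cc2cc(Br)ccc2OCc2ccccc2)cc1C(F)(F)F` carries trifluoromethyl in place of hydrogen on an aromatic carbon. For compound 2 the assay reports only a limit, < 2000 nM, and not a number. Because of the limit of < 2000 nM in this assay, at which 1 of the 3 values shown sits, the step that the limit leaves unreadable from compound 1 to compound 2 cannot be read in size, so this change has no measured magnitude in this assay.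

Compound 3 `Cc1cc(C(=O)O)nn1Cc1cc(Br)ccc1OCc1cccc(C(F)(F)F)c1` stands on a different core; the difference between the core of compound 3 and that of compound 1 is not broken down here. In this assay compound 3 gives 1100 nM, the highest of the two numbers given, and a value that lies well beyond the scatter above that of compound 1.

Compound 4 `Cc1cc(C(=O)O)nn1Cc1cc(Br)ccc1OCc1cc(C(F)(F)F)cc(C(F)(F)F)c1` has not yet been measured. It differs from compound 3 by trifluoromethyl in place of hydrogen on an aromatic carbon. Among the compounds with values here, this is the same kind of change as the one from compound 1 to compound 2, but not the same: there the trifluoromethyl entered on a five-membered aromatic ring with 2 nitrogen, here it enters on a six-membered aromatic ring of carbon only, so the earlier pair offers no direct guide to its size. Since compound 3 already sits at 1100 nM, the step of a 1.8-fold higher number from compound 3 to compound 4 (0.26 log units; within the scatter) is expected to be small and toward a weaker inhibitor. In this assay compound 4 is therefore estimated at 2000 nM, with a range from 700 nM to 6000 nM, and a real chance that only a limit is reported.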

Compound 4, inhibition constant: < 2000 nM
Compound 4 was reported as a limit; the forecaster's own chance of this, stated with the estimate: 35%; the middle value sits exactly at the limit.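

In this assay compound 4 is reported only as a limit, < 2000 nM, and not as a number. The step from compound 3 to compound 4 therefore cannot be read in size, and no new step arises, because of this limit: the limit of < 2000 nM in this assay, at which 2 of the 4 values shown sit.

The compounds shown leave open how large the effect of the added trifluoromethyl on the six-membered aromatic ring is, and in which direction it runs.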